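A few compounds are considered here, and "the series" means these few. Any claim that something is new, unique, unknown or untested is made for them only; others in the source may bear on it.

Compound 1 `O=C(Nc1ccccc1)c1cn(-c2ccccc2)nc1-c1ccc(Cl)cc1`, compound 2 `O=C(Nc1ccc(Br)cc1)c1cn(-c2ccccc2)nc1-c1ccc(Cl)cc1` and compound 3 `O=C(Nc1ccccc1)c1cn(-c2ccccc2)nc1-c1ccc([N+](=O)[O-])cc1` share one core and were all tested in a functional assay on MCF7 cells (Homo sapiens) for cytotoxicity, read by MTT assay, with a stated time of 48 h; a lower number here means a stronger inhibitor, a higher number a weaker inhibitor. Compound 1 gives 2340 nM, compound 2 gives 5310 nM and compound 3 gives 2260 nM. The change from compound 1 to compound 2 is bromo in place of hydrogen on an aromatic carbon, and it made a 2.3-fold higher number from compound 1 to compound 2 (0.36 log units; beyond the scatter). The difference between the cores of compound 1 and compound 3 is nitro in place of chloro on an aromatic carbon, which made a 1.0-fold lower number from compound 1 to compound 3 (0.02 log units; within the scatter), so the two cores cannot be told apart on this read-out. Compound 4 `O=C(Nc1ccc(Br)cc1)c1cn(-c2ccccc2)nc1-c1ccc([N+](=O)[O-])cc1` has not yet been measured; it differs from compound 3 by bromo in place of hydrogen on an aromatic carbon, the same change already made from compound 1 to compound 2. In this assay the step expected is a 2.2-fold higher number from compound 3 to compound 4 (0.34 log units; beyond the scatter), because the earlier identical change gave a 2.3-fold higher number from compound 1 to compound 2 (0.36 log units; beyond the scatter). Compound 4 is therefore estimated at 5000 nM, with a likely range from 2500 nM to 10000 nM.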

Compound 4, half-maximal inhibitory concentration: 5300 nM
Compound 4: the middle estimate sits 1.1-fold (0.03 log units) below what was measured; measured number inside the range.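

In this assay, putting bromo on the core of compound 3 gave a 2.3-fold higher number from compound 3 to compound 4 (0.37 log units; beyond the scatter), which matches the step seen on the core of compound 1: the same change on two cores in this assay, a 2.3-fold higher number (0.36 log units; beyond the scatter) from compound 1 to compound 2 and a 2.3-fold higher number (0.37 log units; beyond the scatter) from compound 3 to compound 4, 1.0-fold (0.01 log units) apart, within the scatter of two such steps. Replacing chloro with nitro while the 4-bromophenyl group stayed in place gave a 1.0-fold lower number from compound 2 to compound 4 (0.00 log units; within the scatter), again matching the earlier swap: the same change on two cores in this assay, a 1.0-fold lower number (0.02 log units; within the scatter) from compound 1 to compound 3 and a 1.0-fold lower number (0.00 log units; within the scatter) from compound 2 to compound 4, 1.0-fold (0.01 log units) apart, within the scatter of two such steps. Across these four compounds, each change carried over unaltered from one core to the other, but this rests on two cores in this assay alone and does not show why bromo gives the higher number.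

The compounds shown leave open whether a different group in place of bromo, such as an amine or a methoxy group, would carry over in the same way.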